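Swapping a halogenated ring on a hydrazide scaffold

A few compounds are considered here, and "the series" means these few. Any claim that something is new, unique, unknown or untested is made for them only; others in the source may bear on it.

Four compounds share a hydrazide backbone that carries a sulfonamide-linked heterocycle on one side and a halogenated phenyl ring on the other. Compound 1 `O=C(NNC(=O)c1cccc(Cl)c1)c1ccc(NS(=O)(=O)c2cnc(O)nc2O)cc1` and compound 2 `O=C(NNC(=O)c1ccccc1F)c1ccc(NS(=O)(=O)c2cnc(O)nc2O)cc1` place the sulfonamide-bearing group at one position of the central ring; compound 3 `O=C(NNC(=O)c1cccc(NS(=O)(=O)c2cnc(O)nc2O)c1)c1cccc(Cl)c1` and compound 4 `O=C(NNC(=O)c1ccccc1F)c1cccc(NS(=O)(=O)c2cnc(O)nc2O)c1` place it differently, and the difference between the two cores is not broken down here.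

In a functional assay on SGC-7901 cells (Homo sapiens) for antiproliferative activity, read by MTT assay, with a stated time of 24 h (on this read-out lower numbers stand for stronger inhibition and higher numbers for weaker inhibition), compound 1 gives 8610 nM. For compound 2 the result in this assay is a limit rather than a number, > 20000 nM. Compound 3 gives 7310 nM in this assay, a value that sits within the usual scatter of the value of compound 1, so the two cannot be ranked against each other.

The change from compound 1 to compound 2 is 2-fluorophenyl in place of 3-chlorophenyl on a carbonyl carbon, and it produced an at least 2.3-fold higher number from compound 1 to compound 2 (0.36 log units; beyond the scatter). The change from compound 3 to compound 4 is 2-fluorophenyl in place of 3-chlorophenyl on a carbonyl carbon, the same change on the other core.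

Compound 4 has not yet been measured in this assay. Its value is expected to move by roughly a 2.7-fold higher number from compound 3 to compound 4 (0.44 log units; beyond the scatter), on the ground that the same change from compound 1 to compound 2 gave an at least 2.3-fold higher number from compound 1 to compound 2 (0.36 log units; beyond the scatter) and ended at the limit (the limit of > 20000 nM in this assay, at which 1 of the 3 values shown sits). Compound 4 is therefore estimated at about 20000 nM, with a likely range from 10000 nM to 50000 nM, and a fair chance that only a limit is reported.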

Compound 4, half-maximal inhibitory concentration: > 20000 nM
Compound 4: only a limit was reported; the forecaster's own chance of this, stated with the estimate: 55%; the middle value sits exactly at the limit.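

In this assay compound 4 gives > 20000 nM, which is a limit and not a number, and it is the same limit as the one reported for compound 2: the limit of > 20000 nM in this assay, at which 2 of the 4 values shown sit.

Putting 2-fluorophenyl in place of 3-chlorophenyl on a carbonyl carbon gives an at least 2.7-fold higher number from compound 3 to compound 4 (0.43 log units; beyond the scatter), so in these two pairs the direction of the change carries over from one core to the other, with the 3-chlorophenyl compound giving the lower number each time. What this does not show is whether the change has the same size on both cores, since the true values of the two 2-fluorophenyl compounds remain unknown: the same change on two cores in this assay, an at least 2.3-fold higher number (0.36 log units; beyond the scatter) from compound 1 to compound 2 and an at least 2.7-fold higher number (0.43 log units; beyond the scatter) from compound 3 to compound 4; the limit leaves it open whether they differ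

The swap alters both the halogen and its place on the ring in a single step, so the compounds shown cannot separate these two parts of the change. They also leave open how the series would respond if an amine, a carboxylic acid or a longer chain stood on this phenyl ring instead of a halogen, and whether such a group would behave alike on both cores.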